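The source may hold more compounds than are shown below. What is called first, only, known or untested is meant among the compounds shown, and "the series" means these compounds.

Compound 1 `Nc1cc(-c2cccc(-n3ccc4cc(C5CC5)cc(F)c4c3=O)c2CO)nc(Nc2cnn(C3CC3)c2)n1` and compound 2 `Nc1cc(-c2cccc(-n3ccc4cc(C5CC5)cc(F)c4c3=O)c2CO)nc(Nc2cnn(CC3CC3)c2)n1` share one core and differ only in the group on an aromatic nitrogen. In a physicochemical assay for solubility, read by LC-MS, in phosphate buffer, measured as kinetic solubility, with a stated time of 1 h, at pH 7.4 (a higher number here means a more soluble compound, a lower number a less soluble compound), compound 1 gives 9800 nM, while compound 2 gives 6300 nM. The step of a 1.6-fold lower number from compound 1 to compound 2 (0.19 log units; within the scatter) lies within the scatter, so compound 2 stands at the lower of the two numbers without a real difference from compound 1. Compound 3 `Cn1cc(Nc2nc(N)cc(-c3cccc(-n4ccc5cc(C6CC6)cc(F)c5c4=O)c3CO)n2)cn1` is reached from compound 2 by hydrogen in place of cyclopropyl on a saturated chain carbon bound to an aromatic nitrogen. Within the data shown here, the one measured step, adding a carbon between cyclopropyl and the nitrogen, moved little, and removing the cyclopropyl is expected to move little as well. Compound 3 is therefore expected to give 8000 nM in this assay, between 4000 nM and 16000 nM. The expected step of a 1.3-fold higher number from compound 2 to compound 3 (0.10 log units; within the scatter) stays within the scatter.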

Compound 3, solubility: 18000 nM
Estimate against measurement, compound 3: 2.3-fold (0.35 log units) below; the measured number lies above the stated range.
By their numbers in this assay, from the lowest: compounds 2, 1 and 3 (each within the scatter of the next, the first and the last beyond it).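

Among these compounds, at this aromatic nitrogen, the change from cyclopropylmethyl to methyl gives a 2.9-fold higher number from compound 2 to compound 3 (0.46 log units; beyond the scatter) in this assay and is the first step here to clear the scatter, though only modestly. Methyl in place of cyclopropyl gives a 1.8-fold higher number from compound 1 to compound 3 (0.26 log units; within the scatter) and stays within the scatter, so compound 1 and compound 3 cannot be told apart. Nothing measured here offers an explanation for the step between compound 2 and compound 3. Still open, as far as these compounds go, is how a longer chain such as n-propyl would read at this nitrogen. From the compounds shown here alone, a chain ending in an amine or a carboxylic acid is equally open.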